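This account rests on a few compounds, and the source may have more. Where it says the series, first, only, none or still open, it means among the compounds named here.

Measured so far:
- compound 1, `O[C@@H]1[C@@H](O)CN[C@H]1c1ccc(-c2ccccc2)cc1`: 0%
- compound 2, `Cc1ccc([C@@H]2NC[C@H](O)[C@H]2O)cc1`: 0.4%

Both compounds were tested in an assay on isolated protein for inhibition of alpha-mannosidase (Canavalia ensiformis), read by spectrophotometry, tested at 1000 uM; a lower number here means less inhibition, a higher number more inhibition at the concentration tested (going by the name of the read-out). Compound 1 gives 0%, and compound 2 gives 0.4%. Going by the values given here, the only step between them, a number 0.4 percentage points higher from compound 1 to compound 2 (within the scatter), lies within the scatter, so the two numbers cannot be told apart; compound 2 stands at the top of these two numbers only on paper, with compound 1 sitting within the scatter of it.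

Compound 3, `O[C@@H]1[C@@H](O)CN[C@H]1c1ccc(F)cc1`, has not yet been measured. It differs from compound 2 by fluoro in place of methyl on an aromatic carbon, on an aromatic carbon of a six-membered aromatic ring of carbon only. Among the compounds with values here, the one measured step concerns the same aromatic carbon, where methyl replaced phenyl, and it left the read-out within the scatter. Nothing measured here bears on fluoro at this carbon. On this basis the expected step of a number 0.1 percentage points higher from compound 2 to compound 3 (within the scatter) is none beyond the scatter. Compound 3 is therefore estimated at 0.5%, with a range from 0% to 10%.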

Compound 3, a percentage reported as inhibition, at one concentration (the size of the read-out at that concentration, not a potency): 1.2%
Beside the measured number, compound 3's estimate is 0.7 percentage points below it; measured number inside the range.
By their numbers in this assay, from the lowest: compounds 1, 2 and 3 (each within the scatter of the next).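

In this assay, the change from methyl to fluoro gives a number 0.8 percentage points higher from compound 2 to compound 3 (within the scatter), and the change from phenyl to fluoro gives a number 1.2 percentage points higher from compound 1 to compound 3 (within the scatter). The earlier step swapped one carbon group for another, whereas fluoro puts a different element on this aromatic carbon, and the read-out still does not separate it from either carbon group, so phenyl, methyl and fluoro at this position cannot be told apart in this test. No measurement shown offers an explanation for this flat result.

On these data alone, whether a different kind of group on this aromatic carbon, such as an amine, a carboxylic acid or a longer chain, would move the read-out beyond the scatter remains open. Also open, as far as these compounds go, are whether fluoro at another carbon of the ring would behave in the same way, and whether a change to the shared core itself, rather than to this aromatic substituent, would give a number that can be told apart from those of these three compounds.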